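The source may report more compounds than this note shows. Statements on the series, on what has been measured and on what is new or still open speak of the compounds shown alone.

Compound 3 `CCCOc1nc(N)nc2c1ncn2/C=C1/CC1(CO)CO` is known in an ADME assay on MOLT-3 cells (Homo sapiens) for cytotoxicity, with a stated time of 7 days (a higher number here means that more compound is tolerated, a lower number that less compound is tolerated), only as a limit: compound 3 gives > 20000 nM, which is a limit of the assay and not a number. Compound 1 `CCCCCCCCOc1nc(N)nc2c1ncn2/C=C1/CC1(CO)CO` is likewise known only as a limit, and in this assay compound 1 gives > 20000 nM. Compound 2 `Nc1nc(NC2CC2)c2ncn(/C=C3/CC3(CO)CO)c2n1` is also known only as a limit, and in this assay compound 2 gives > 20000 nM. All three measured values thus share (the limit of > 20000 nM in this assay, at which 3 of the 3 values shown sit), so none of the three compounds can be placed relative to another.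

The steps between them, a step that the two limits leave unreadable from compound 1 to compound 2, a step that the two limits leave unreadable from compound 1 to compound 3 and a step that the two limits leave unreadable from compound 2 to compound 3, are accordingly of unreadable size; both ends of each sit at the limit, and no direction can be taken from them.

Compound 4 `Nc1nc(NCc2ccccc2)c2ncn(/C=C3/CC3(CO)CO)c2n1` differs from compound 3 by benzylamino in place of propoxy on an aromatic carbon. Within the data shown here, the only steps that bear on the change at this aromatic carbon are the unreadable ones just named; they show that an octyloxy, a cyclopropylamino and a propoxy group at that place all leave the compound at the limit in this assay, and nothing in the data points either way for a benzylamino group. Compound 4 is therefore expected to sit at the limit as well, the estimated step being a step that the limit leaves unreadable from compound 3 to compound 4. The estimate for compound 4 is 25000 nM, with a range from 10000 nM to 60000 nM.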

Compound 4, half-maximal cytotoxic concentration: > 20000 nM
Compound 4: a limit, no number; the forecaster's own chance of this, stated with the estimate: 85%; the middle value lies beyond the limit too.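

Among these compounds, compound 4 stands at the same limit as compound 1, compound 2 and compound 3, so none of the steps to compound 4 can be read and no new step emerges: the limit of > 20000 nM in this assay, at which 4 of the 4 values shown sit. The compounds shown leave open at what concentration any of them becomes cytotoxic in this assay, and whether the group on the aromatic carbon changes that at all.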